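A cyclopropyl in place of the phenyl on compound 3

The compounds below may be only part of what the source reports. "The series", "measured", "known", "first", "only" and "open" are said of these compounds alone.

Measured so far in a functional assay for antagonist activity at Alpha-1A adrenergic receptor (Oryctolagus cuniculus); on this read-out higher numbers stand for weaker binding and lower numbers for tighter binding:
compound 1, `CN(C)C(=O)c1cccnc1NCCCN1CCN(c2ccccc2C#N)CC1`, gives 2 nM;
compound 2, `CCOc1ccccc1N1CCN(CCCNc2ncccc2C(=O)N(C)C)CC1`, gives 0.501 nM;
compound 3, `CN(C)C(=O)c1cccnc1NCCCN1CCN(c2ccccc2-c2ccccc2)CC1`, gives 1.26 nM.

Compound 3 stands second highest of the three numbers. Its nearest neighbour is compound 1, a step within the scatter (a 1.6-fold lower number from compound 1 to compound 3 (0.20 log units; within the scatter)), while compound 2 lies further away (a 2.5-fold higher number from compound 2 to compound 3 (0.40 log units; beyond the scatter)).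

Compound 4, `CN(C)C(=O)c1cccnc1NCCCN1CCN(c2ccccc2C2CC2)CC1`, differs from compound 3 in one place: cyclopropyl in place of phenyl on an aromatic carbon, on an aromatic carbon of a six-membered aromatic ring of carbon only, ortho to a large group.

Among the measured compounds shown here, no measured step swaps phenyl for cyclopropyl. The steps that touch this position are a 4.0-fold lower number from compound 1 to compound 2 (0.60 log units; beyond the scatter), a 1.6-fold lower number from compound 1 to compound 3 (0.20 log units; within the scatter) and a 2.5-fold higher number from compound 2 to compound 3 (0.40 log units; beyond the scatter): three different groups there span only a modest range. A cyclopropyl is therefore expected to keep compound 4 close to compound 3, with no step beyond the scatter, a 1.3-fold lower number from compound 3 to compound 4 (0.10 log units; within the scatter).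

The expected value for compound 4 in this assay is 1 nM, within a range from 0.4 nM to 3 nM.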

Compound 4, dissociation constant: 0.631 nM
Compound 4: middle estimate off by 1.6-fold (0.20 log units), on the high side, within the range that was stated.
By their numbers in this assay, from the lowest: compounds 2, 4, 3 and 1 (each within the scatter of the next, the first and the last beyond it).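

Swapping phenyl for cyclopropyl, with 3 heavy atoms in place of 6, gives a 2.0-fold lower number from compound 3 to compound 4 (0.30 log units; within the scatter) in this assay, so at this place a much smaller carbon-only ring still gives a number that cannot be told apart from that of the larger ring. Cyclopropyl also cannot be told apart from ethoxy here, at a 1.3-fold higher number from compound 2 to compound 4 (0.10 log units; within the scatter), even though one group is a carbon-only ring and the other is not. Among the compounds shown here, only the nitrile-bearing compound stands apart, at a 3.2-fold lower number from compound 1 to compound 4 (0.50 log units; beyond the scatter), the one step of these three that lies beyond the scatter.

Nothing available explains why these groups give these numbers. Going by these compounds, it remains open whether an amine or a carboxylic acid at this place would stay within the same modest range, and whether a group as small as methyl would.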